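From difluorophenyl to bromophenyl on the shared core

A few compounds are considered here, and "the series" means these few. Any claim that something is new, unique, unknown or untested is made for them only; others in the source may bear on it.

All three measured compounds were tested in a functional assay on CFPAC-1 cells (Homo sapiens) for inhibition, read by MTT assay, with a stated time of 72 h; a lower number here means a stronger inhibitor, a higher number a weaker inhibitor.
Compound 1 `O=c1cc(Cn2cc(CCCCO)nn2)c2ccc(O)cc2o1` gives > 100000 nM, a limit of the assay.
Compound 2 `CCCCCCCCc1cn(Cc2cc(=O)oc3cc(O)ccc23)nn1` gives 62700 nM.
Compound 3 `O=c1cc(Cn2cc(-c3cc(F)cc(F)c3)nn2)c2ccc(O)cc2o1` gives > 100000 nM, a limit of the assay.

Compound 3 thus stands at the limit of > 100000 nM in this assay, at which 2 of the 3 values shown sit, so its position among the numbers is a limit rather than a number. Compound 4 `O=c1cc(Cn2cc(-c3ccc(Br)cc3)nn2)c2ccc(O)cc2o1` differs from it by 4-bromophenyl in place of 3,5-difluorophenyl on an aromatic carbon. For the measured compounds named here, no measured step exchanges one aryl group for another; the nearest are an at least 1.5-fold higher number from compound 2 to compound 3 (0.20 log units; that floor lies within the scatter), where an aryl group entered on the same carbon, and a step that the two limits leave unreadable from compound 1 to compound 3. Both end at the limit. The step is expected to be a number no higher from compound 3 to compound 4 (the limit leaves the size open), nothing beyond the scatter. The estimate for compound 4 in this assay is 100000 nM, ranging from 40000 nM to 300000 nM.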

Compound 4, half-maximal inhibitory concentration: 52900 nM
The estimate for compound 4 lay 1.9-fold (0.28 log units) above the measured number; the measured number falls inside the stated range.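

Unlike compound 3, compound 4 carries an aryl group on this aromatic carbon and still gives a number in this assay, though the change amounts only to an at least 1.8-fold lower number from compound 3 to compound 4 (0.27 log units; that floor lies within the scatter). Set against the chains, 4-bromophenyl gives a 1.2-fold lower number from compound 2 to compound 4 (0.07 log units; within the scatter) and an at least 1.8-fold lower number from compound 1 to compound 4 (0.27 log units; that floor lies within the scatter), so an aryl group can match octyl here. The steps from compound 1 and compound 3 offer only floors: the limit of > 100000 nM in this assay, at which 2 of the 4 values shown sit.

The compounds shown leave open how 4-chlorophenyl or 4-methoxyphenyl would behave on this carbon. They also leave open what an amine or a carboxylic acid at the end of the chain would give.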